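From cyclopropylmethyl to cyclobutyl: an expected half-life

The source may hold more compounds than are shown below. What is called first, only, known or untested is meant among the compounds shown, and "the series" means these compounds.

In an ADME assay on microsomes from liver (Homo sapiens) for metabolic stability, read by LC-MS, using NADPH, with a stated time of 10 min, tested at 10 uM (a lower number here means that the compound disappears faster, a higher number that the compound lasts longer), compound 2 `Nc1ncnc2c1c(Oc1cc(C(F)(F)F)ccn1)nn2CC1CC1` gives 1.87 h, the higher of the two actual numbers, while compound 3 `Nc1ncnc2c1c(Oc1cc(Cl)ccn1)nn2[C@H]1C[C@H](F)C1` gives 0.833 h. Compound 1 `Nc1ncnc2c1c(Oc1cc(C(F)(F)F)ccn1)nn2C1CC1` shows > 2.41 h, which is a limit of the assay and not a number. Compound 4 `Nc1ncnc2c1c(Oc1cc(C(F)(F)F)ccn1)nn2C1CCC1` has the same atoms as compound 2, joined differently, with cyclobutyl in place of cyclopropylmethyl on an aromatic nitrogen. Within the data shown here, the one measured step at this nitrogen is an at least 1.2-fold lower number from compound 1 to compound 2 (0.11 log units; that floor lies within the scatter), and it puts cyclopropylmethyl in place of cyclopropyl. Going by that small step alone, the expected change is a 1.0-fold higher number from compound 2 to compound 4 (0.01 log units; within the scatter), nothing beyond the scatter. For compound 4 the estimated half-life is 1.9 h, with an expected range from 1 h to 3.5 h.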

Compound 4, half-life: 1.02 h
For compound 4 the middle estimate is 1.9-fold (0.27 log units) above the measured one, within the range that was stated.
By their numbers in this assay, from the lowest: compounds 3, 4 and 2 (each within the scatter of the next, the first and the last beyond it). At a limit, above all of these: compound 1.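

In this assay, a change that keeps the same atoms but joins them differently, cyclobutyl in place of cyclopropylmethyl, gives a 1.8-fold lower number from compound 2 to compound 4 (0.26 log units; within the scatter), so this change cannot be told apart from the scatter. Cyclobutyl in place of cyclopropyl gives an at least 2.3-fold lower number from compound 1 to compound 4 (0.37 log units; beyond the scatter), the first step at this nitrogen that clearly clears the scatter. That size is only a floor, because compound 1 stands at a limit of the assay and not at a number: the limit of > 2.41 h in this assay, at which 1 of the 4 values shown sits.

From the compounds shown here alone, how the half-life responds to an open-chain group such as isopropyl on this nitrogen remains open.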